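Oxolane to oxane on the amide carbonyl of compound 1

The source may hold more compounds than are shown below. What is called first, only, known or untested is meant among the compounds shown, and "the series" means these compounds.

Within the data shown here, compound 1 `Cc1cc(N2CC[C@H](N3CCC[C@@H]3C)C2)ccc1NC(=O)C1CCCO1` gives 7.33 nM in an assay on CHO cells for displacement of a labelled ligand from histamine receptor H3 (Macaca mulatta) (a lower number here means a stronger inhibitor, a higher number a weaker inhibitor), the lowest of the three numbers so far. Compound 3 `CC(=O)N1CCCC1C(=O)Nc1ccc(N2CCC(N3CCCC3C)C2)cc1` gives 14.1 nM, within the scatter of compound 1. Compound 2 `CC1CCCN1C1CCN(c2ccc(NC(=O)C3C(C)(C)C3(C)C)cc2)C1` gives 144 nM, the furthest from compound 1. Among the measured compounds shown here, the single measured step, a 10-fold lower number from compound 2 to compound 3 (1.01 log units; beyond the scatter), alters the group on the amide carbonyl, the same place that changes in compound 4 `Cc1cc(N2CC[C@H](N3CCC[C@@H]3C)C2)ccc1NC(=O)C1CCOCC1`: oxan-4-yl in place of oxolan-2-yl on a carbonyl carbon. That step involves different groups and does not settle the present case; it shows only that this position can move the number strongly. Compound 1 and compound 3 carry different groups there yet give close numbers. A step of a 1.4-fold higher number from compound 1 to compound 4 (0.13 log units; within the scatter) is therefore expected, within the scatter. For compound 4 the estimate is 10 nM, between 3 nM and 35 nM.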

Compound 4, inhibition constant: 0.97 nM
Compound 4: the middle estimate sits 10-fold (1.01 log units) above what was measured; the whole stated range lies above it.
By their numbers in this assay, from the lowest: compound 4; then compounds 1 and 3 (each within the scatter of the next); then compound 2.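

In this assay, this position on the carbonyl carbon responds to a small change within saturated oxygen rings: oxan-4-yl in place of oxolan-2-yl gives a 7.6-fold lower number from compound 1 to compound 4 (0.88 log units; beyond the scatter). The step lies beyond the scatter, although the two groups have the same count of hydrogen-bond donors and acceptors and no net charge. No measurement bears on the reason for the step.

Still open, as far as these compounds go, is whether the ring size or the place of the ring oxygen sets the number. A cyclohexyl or piperidin-4-yl group on the same carbonyl carbon would test the need for that oxygen.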